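Swapping the aryl group on the saturated ring carbon

The compounds below may be only part of what the source reports. "The series", "measured", "known", "first", "only" and "open" are said of these compounds alone.

Compound 1: `COc1cc(/C=C/C(=O)C2=C(/C=C/c3ccc(O)c(OC)c3)NC(=S)NC2c2ccc(C)cc2)ccc1O`, 10.2%
Compound 2: `COc1cc(/C=C/C(=O)C2=C(/C=C/c3ccc(O)c(OC)c3)NC(=S)NC2c2ccccc2O)ccc1O`, 34%

In a functional assay, with a stated time of 20 min, tested at 2 uM (a higher number here means a stronger effect of the compound at the concentration tested, a lower number a weaker effect), compound 2 gives 34%, the higher of the two numbers; compound 1 gives 10.2%. Going by the values given here, the only measured step, a number 23.8 percentage points higher from compound 1 to compound 2 (beyond the scatter), bears on the change to compound 3 `COc1cc(/C=C/C(=O)C2=C(/C=C/c3ccc(O)c(OC)c3)NC(=S)NC2c2ccc(N(C)C)cc2)ccc1O`: 4-(dimethylamino)phenyl in place of 2-hydroxyphenyl on a saturated ring carbon. Since compound 1 with its 4-methylphenyl sits at 10.2%, a group without the hydroxyl is expected to give a step of a number 16 percentage points lower from compound 2 to compound 3 (beyond the scatter), downward. Compound 3 is therefore estimated at 18%, ranging from 6% to 34%.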

Compound 3, a percentage reported as activity, at one concentration (the size of the read-out at that concentration, not a potency): 32.3%
Estimate against measurement, compound 3: 14.3 percentage points below; the measured number falls inside the stated range.
By their numbers in this assay, from the lowest: compound 1; then compounds 3 and 2 (each within the scatter of the next).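

In this assay, the 2-hydroxyphenyl group can give way to 4-(dimethylamino)phenyl with a number 1.7 percentage points lower from compound 2 to compound 3 (within the scatter), so among these compounds a hydroxyl on the aryl group is not required for this level of effect. Dimethylamino in place of methyl on the aromatic carbon gives a number 22.1 percentage points higher from compound 1 to compound 3 (beyond the scatter), which shows that a group without a hydrogen-bond donor can still separate from 4-methylphenyl. Nothing available explains these differences. Open, as far as these compounds go, is how an aryl group carrying a primary amine or a carboxylic acid would read at this position.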